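A few compounds are considered here, and "the series" means these few. Any claim that something is new, unique, unknown or untested is made for them only; others in the source may bear on it.

Measured in an assay on HEK293 cells for displacement of a labelled ligand from Orexin receptor type 2 (Homo sapiens), read by scintillation counting, with a stated time of 90 min; on this read-out higher numbers stand for weaker inhibition and lower numbers for stronger inhibition:
compound 1 `COc1ccc(N2C(=O)N(Cc3ccc(F)cc3Cl)c3ccccc3S2(=O)=O)cc1OC` gives 25.1 nM
compound 2 `COc1ccc(N2C(=O)N(Cc3c(F)cc(F)cc3Cl)c3ccccc3S2(=O)=O)cc1OC` gives 1 nM
compound 3 `COc1ccc(N2C(=O)N(Cc3c(F)cc(F)cc3OC)c3ccccc3S2(=O)=O)cc1OC` gives 6.31 nM

Compound 3 stands second highest of the three numbers: a 4.0-fold lower number from compound 1 to compound 3 (0.60 log units; beyond the scatter) separates it from compound 1, and a 6.3-fold higher number from compound 2 to compound 3 (0.80 log units; beyond the scatter) from compound 2.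

Compound 4 `COc1ccc(N2C(=O)N(Cc3ccccc3)c3ccccc3S2(=O)=O)cc1OC` is not yet measured. The change from compound 3 is phenyl in place of 2,4-difluoro-6-methoxyphenyl on a saturated chain carbon bound to an amide-type nitrogen in a ring, so every substituent on that ring is removed at once. Going by the values given here, two measured steps bear on it. Adding a single fluoro on this ring gave a 25-fold lower number from compound 1 to compound 2 (1.40 log units; beyond the scatter), a large step, so taking both fluoro atoms away should cost heavily. Among the compounds with values here, exchanging chloro for methoxy gave a 6.3-fold higher number from compound 2 to compound 3 (0.80 log units; beyond the scatter), showing the remaining substituent also matters, though no step removes it entirely. A rise in this assay well beyond the scatter is therefore expected, of a size at least comparable with the fluoro step, i.e. a 24-fold higher number from compound 3 to compound 4 (1.38 log units; beyond the scatter).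

Compound 4 is estimated at 150 nM, with a range from 30 nM to 800 nM.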

Compound 4, inhibition constant: 79.4 nM
Compound 4: the middle estimate sits 1.9-fold (0.28 log units) above what was measured; measured number inside the range.
By their numbers in this assay, from the lowest: compound 2; then compound 3; then compound 1; then compound 4.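

In this assay, phenyl at this position gives a higher number than each of the three substituted rings: the change to it is large from the 2,4-difluoro-6-methoxyphenyl ring (a 13-fold higher number from compound 3 to compound 4 (1.10 log units; beyond the scatter)) and from the 2-chloro-4,6-difluorophenyl ring (a 79-fold higher number from compound 2 to compound 4 (1.90 log units; beyond the scatter)), and modest from the 2-chloro-4-fluorophenyl ring (a 3.2-fold higher number from compound 1 to compound 4 (0.50 log units; beyond the scatter)). Going by these compounds alone, this gives the series its unsubstituted reference point, showing that all three substitution patterns on the ring, including the methoxy-bearing one, lower the number, with no compound here going against that. No measurement shown accounts for these differences.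

On these data alone, the separate contribution of each substituent remains open, as every step to phenyl removes several together. Also open, as far as these compounds go, is whether an amine or a carboxylic acid on the phenyl, or a longer chain in place of the saturated chain carbon, would be tolerated.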